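Working notes: formyl in place of chloromethyl

This account rests on a few compounds, and the source may have more. Where it says the series, first, only, none or still open, it means among the compounds named here.

Compound 1 `COCOc1cc(=O)oc2cc(OCc3cccc(Cl)c3)ccc12` gives 23% in an assay on isolated protein (strain Sprague-Dawley) for inhibition of Amine oxidase [flavin-containing] A (Rattus norvegicus), read by spectrophotometry, with a stated time of 5 min, tested at 10 uM; on this read-out lower numbers stand for less inhibition and higher numbers for more inhibition at the one concentration tested (going by the name of the read-out). Compound 2 `CCOC(=O)Nc1cc(=O)oc2cc(OCc3cccc(Cl)c3)ccc12` gives 21% in this assay. Compound 3 `O=c1cc(CCl)c2ccc(OCc3cccc(Cl)c3)cc2o1` gives 21% in this assay.

Compound 3 stands level with compound 2 at the digits printed, the two together the lowest of the three numbers: nearest is compound 2, with no change at the digits printed from compound 2 to compound 3 (within the scatter); furthest is compound 1, with a number 2 percentage points lower from compound 1 to compound 3 (within the scatter).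

Compound 4 `O=Cc1cc(=O)oc2cc(OCc3cccc(Cl)c3)ccc12` differs from compound 3 by formyl in place of chloromethyl on an aromatic carbon. The three steps that swap the group on this same aromatic carbon, a number 2 percentage points lower from compound 1 to compound 2 (within the scatter), a number 2 percentage points lower from compound 1 to compound 3 (within the scatter) and no change at the digits printed from compound 2 to compound 3 (within the scatter), all stay within the scatter, so the step to compound 4 is expected to show no movement beyond the scatter either, no change at the digits printed from compound 3 to compound 4 (within the scatter).

Compound 4 is therefore estimated at 21%, with a range from 9% to 34%.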

Compound 4, a percentage reported as inhibition, at one concentration (the size of the read-out at that concentration, not a potency): 14%
The estimate for compound 4 lay 7 percentage points above the measured number; the measured number falls inside the stated range.
By their numbers in this assay, from the lowest: compounds 4, 2, 3 and 1 (each within the scatter of the next).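

On this aromatic carbon opposite the ring oxygen, formyl stays within the scatter of the other groups in this assay, with a number 7 percentage points lower from compound 3 to compound 4 (within the scatter) and a number 7 percentage points lower from compound 2 to compound 4 (within the scatter) and also a number 9 percentage points lower from compound 1 to compound 4 (within the scatter) in this read-out. Even the largest of these steps leaves the four groups inseparable at this position, so swapping chloromethyl for formyl gives no measurable difference. Nothing available accounts for these numbers.

Going by these compounds, whether an amine, a carboxylic acid or a longer chain on this carbon would give a number beyond the scatter remains open.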